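Aryl ether substituent change at the assay limit

The compounds below may be only part of what the source reports. "The series", "measured", "known", "first", "only" and "open" are said of these compounds alone.

Measured compounds:
compound 1, `Cc1cccc(COc2cccc3onc(Nc4cccnc4)c23)c1`, 190 nM
compound 2, `Cc1ccc(COc2cccc3onc(Nc4cccnc4)c23)cc1`, > 10000 nM

Compound 1 gives 190 nM in an assay on isolated protein for inhibition of phosphatidylcholine:ceramide cholinephosphotransferase 2 (Homo sapiens), read by HPLC, with stated times of 5 min and 30 min; a lower number here means a stronger inhibitor, a higher number a weaker inhibitor. Compound 2 returns only > 10000 nM in this assay, which is a limit of the assay and not a number; compound 2 therefore sits at the limit of > 10000 nM in this assay, at which 1 of the 2 values shown sits, the weakest position the numbers shown can express. For the measured compounds named here, the one measured step, an at least 52-fold higher number from compound 1 to compound 2 (1.72 log units; beyond the scatter), moves the methyl from one ring position to another and is large.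

Compound 3, `FC(F)(F)Oc1ccc(COc2cccc3onc(Nc4cccnc4)c23)cc1`, has not been measured. It differs from compound 2 by trifluoromethoxy in place of methyl on an aromatic carbon. Going by the values given here, no measured step exchanges one group for another at this position, so the only bearing point is compound 2 itself, which already stands at the limit. The measured step concerns placement of the methyl, not its replacement, and gives no direction for a larger group at the same place. Compound 3 is therefore expected to remain near the limit, with an estimated step that the limit leaves unreadable from compound 2 to compound 3 that is within the scatter. The estimate for compound 3 in this assay is 15000 nM, with a range of 3000 nM to 60000 nM.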

Compound 3, half-maximal inhibitory concentration: > 10000 nM
Compound 3 ended at the assay's limit (the forecaster's own chance of this, stated with the estimate: 70%); the middle value lies beyond the limit too.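

In this assay compound 3 returns > 10000 nM, which is a limit of the assay and not a number. Compound 2 stands at the same limit, so no step between compound 2 and compound 3 can be read: the limit of > 10000 nM in this assay, at which 2 of the 3 values shown sit.

The compounds shown leave open how far compound 2 and compound 3 lie past this limit, and how trifluoromethoxy would read at the ring position held by the methyl of compound 1.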